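Thiazolyl Sulfonyl in Place of Methoxyphenyl Sulfonyl

The source may hold more compounds than are shown below. What is called first, only, known or untested is meant among the compounds shown, and "the series" means these compounds.

Compound 1 `O=C(NC/C=C1\CCCc2cnn(-c3ccc(C(F)(F)F)cc3)c21)NS(=O)(=O)c1cc(Cl)c(Cl)s1`: 4 nM
Compound 2 `COc1ccc(S(=O)(=O)NC(=O)NC/C=C2\CCCc3cnn(Cc4ccc(Cl)cc4Cl)c32)cc1`: 29 nM

In a functional assay on CHO-K1 cells for antagonist activity at prostaglandin E2 receptor EP3 subtype (Homo sapiens), read by TR-FRET and cAMP accumulation, with a stated time of 30 min (a higher number here means a weaker inhibitor, a lower number a stronger inhibitor), compound 2 gives 29 nM, the higher of the two numbers measured. Compound 1 gives 4 nM, a lower number beyond the scatter, but it differs from compound 2 in more than one place, so no single step can be read from the pair. Compound 3 `Cc1ncc(S(=O)(=O)NC(=O)NC/C=C2\CCCc3cnn(Cc4ccc(Cl)cc4Cl)c32)s1` is compound 2 with 2-methyl-1,3-thiazol-5-yl in place of 4-methoxyphenyl on a sulfonyl sulfur. Going by the values given here, no measured pair isolates this change, so the expectation rests on compound 2 alone. A small downward step, if any beyond the scatter, is expected a 1.9-fold lower number from compound 2 to compound 3 (0.29 log units; within the scatter). Compound 3 is estimated at 15 nM, within 4 nM to 60 nM.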

Compound 3, half-maximal inhibitory concentration: 9 nM
Estimate against measurement, compound 3: 1.7-fold (0.22 log units) above; the measured number falls inside the stated range.
By their numbers in this assay, from the lowest: compound 1; then compound 3; then compound 2.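

At this sulfonyl sulfur, whose other neighbour is the amide-type nitrogen, the 4-methoxyphenyl group is not required: in this assay, 2-methyl-1,3-thiazol-5-yl in its place gives a 3.2-fold lower number from compound 2 to compound 3 (0.51 log units; beyond the scatter). This single-place step, the only one shown, indicates that a five-membered aromatic ring with 2 hetero atoms is tolerated here, with fewer heavy atoms than the group it replaces. No available measurement bears on the reason for the step.

As far as these compounds go, it remains open whether the step comes from the ring or from its methyl, which an unsubstituted 1,3-thiazol-5-yl at this sulfonyl sulfur would separate. From the compounds shown here alone, it is also open whether the step would hold on the core of compound 1.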